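This account rests on a few compounds, and the source may have more. Where it says the series, first, only, none or still open, it means among the compounds named here.

Measured in a functional assay on MCF7 cells (Homo sapiens) for antiproliferative activity, read by sulforhodamine B assay, with a stated time of 48 h; a higher number here means a weaker inhibitor, a lower number a stronger inhibitor:
- Compound 1 `COc1ccc(C(=O)/C=C/c2ccccc2-c2ccc(F)nc2)cc1OC`: 41000 nM
- Compound 2 `O=C(/C=C/c1ccccc1-c1ccc(F)nc1)c1cccc(O)c1`: 12000 nM

Compound 2 has the lower of these two numbers, which makes it the stronger inhibitor of the pair, and its gap to compound 1 lies beyond the usual scatter. Compound 3 `COc1ccc(C(=O)/C=C/c2ccccc2-c2ccc(F)nc2)cc1O` differs from compound 2 in one place: methoxy in place of hydrogen on an aromatic carbon, ortho to a hydroxy group and para to a large group (methoxy in place of hydrogen on an aromatic carbon). Within the data shown here, no measured pair shows this change on its own, so any forecast is uncertain. Among the measured compounds shown here, the only hint is that compound 1, which also carries methoxy, gives the higher number, 41000 nM. A small expected rise in this assay, probably within the scatter, is the estimated 1.3-fold higher number from compound 2 to compound 3 (0.12 log units; within the scatter). The expected value for compound 3 is 16000 nM, with an estimated range of 5000 nM to 45000 nM.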

Compound 3, half-maximal inhibitory concentration: 2000 nM
The estimate for compound 3 lay 8.0-fold (0.90 log units) above the measured number; measured number outside the range, below it.
By their numbers in this assay, from the lowest: compound 3; then compound 2; then compound 1.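

In this assay, methoxy at this position, ortho to a hydroxy group and para to a large group, is a clear gain when the neighbouring hydroxy group stays free, with a 6.0-fold lower number from compound 2 to compound 3 (0.78 log units; beyond the scatter) beyond the scatter. That free hydroxy group matters as well: putting a methyl on its oxygen undoes the gain, and removing that methyl gives a 21-fold lower number from compound 1 to compound 3 (1.31 log units; beyond the scatter), the largest step in this small set, so the weak result for compound 1 does not count against methoxy at this position. Nothing shown here explains why either change has such an effect.

Still open, going by these compounds, is whether the gain is specific to methoxy, or whether an ethoxy group, a chlorine atom or an amine at this position would do as well. Also open, on these data alone, is whether an amine could take the place of the neighbouring hydroxy group.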